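A few compounds are considered here, and "the series" means these few. Any claim that something is new, unique, unknown or untested is made for them only; others in the source may bear on it.

Measured so far in a functional assay on IMR-32 cells (Homo sapiens) for antiproliferative activity, read by sulforhodamine B assay, with a stated time of 48 h; a higher number here means a weaker inhibitor of growth, a lower number a stronger inhibitor of growth:
compound 1 `O=C1COc2ccccc2N1CCCn1cc(-c2ccccc2)nn1` gives 370 nM
compound 2 `COc1ccc(-c2cn(CCCN3C(=O)COc4ccccc43)nn2)cc1` gives 49900 nM
compound 3 `O=C1COc2ccccc2N1CCCn1cc(-c2ccccn2)nn1` gives 2000 nM

Compound 3 holds the middle place of the three, with a higher number than compound 1 and a lower number than compound 2. The next compound, compound 4 `O=C1COc2ccccc2N1CCCn1cc(CO)nn1`, carries hydroxymethyl in place of pyridin-2-yl on an aromatic carbon.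

All three measured steps alter the group on this same carbon. Pyridin-2-yl in place of phenyl gave a 5.4-fold higher number from compound 1 to compound 3 (0.73 log units; beyond the scatter) and counts as modest. Methoxy in place of hydrogen gave a 130-fold higher number from compound 1 to compound 2 (2.13 log units; beyond the scatter) and pyridin-2-yl in place of 4-methoxyphenyl gave a 25-fold lower number from compound 2 to compound 3 (1.40 log units; beyond the scatter) and both count as large. The number therefore moves a long way when this group changes. Yet each measured group holds an aromatic ring and hydroxymethyl has none, so no measured step matches this swap.

Among the compounds with values here, the lowest number so far belongs to compound 1 (370 nM) with its plain phenyl, so a modest to large rise in this assay is expected, with wide doubt. The expected change is a 4.0-fold higher number from compound 3 to compound 4 (0.60 log units; beyond the scatter). For compound 4 the estimate is 8000 nM, with an expected range from 1200 nM to 50000 nM.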

Compound 4, concentration for 50% growth inhibition: 5500 nM
Compound 4: the middle estimate sits 1.5-fold (0.16 log units) above what was measured, and the stated range covers the measured number.
By their numbers in this assay, from the lowest: compound 1; then compound 3; then compound 4; then compound 2.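

In this assay, a group with no ring can stand on this carbon of the five-membered aromatic ring without the number climbing to the level of the worst ring-bearing group: hydroxymethyl in place of pyridin-2-yl gives a 2.8-fold higher number from compound 3 to compound 4 (0.44 log units; beyond the scatter). The same group reads very differently against the other two, with hydroxymethyl in place of phenyl giving a 15-fold higher number from compound 1 to compound 4 (1.17 log units; beyond the scatter) and hydroxymethyl in place of 4-methoxyphenyl giving a 9.1-fold lower number from compound 2 to compound 4 (0.96 log units; beyond the scatter), so an aromatic ring here is no guarantee of a low number, as the 4-methoxyphenyl of compound 2 shows, although the lowest number still belongs to the phenyl of compound 1. Nothing measured here explains this order of the four groups.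

The compounds shown leave open whether the oxygen of hydroxymethyl matters or whether a small group of any kind would read the same, a question that a plain methyl, an aminomethyl or a carboxylic acid on this carbon would address. They also leave open how a longer chain ending in a hydroxyl would compare, and whether a methoxy group elsewhere on the phenyl ring would raise the number as much as the 4-methoxyphenyl does.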